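Swapping methyl for chloro on a weakly active compound

The source may report more compounds than this note shows. Statements on the series, on what has been measured and on what is new or still open speak of the compounds shown alone.

Measured in a functional assay on HepG2 cells (Homo sapiens) for antiproliferative activity, read by MTT assay, with a stated time of 72 h; on this read-out lower numbers stand for stronger inhibition and higher numbers for weaker inhibition:
Compound 1 `Cc1ccc(N2C(=O)COc3ccc(-c4cnc5ccccc5c4)cc32)cc1`: > 40000 nM (a limit, not a number)
Compound 2 `O=C1COc2ccc(-c3ccc(O)cc3)cc2N1`: 38200 nM
Compound 3 `COc1ncc(-c2ccc3c(c2)N(c2ccc(Cl)cc2)C(=O)CO3)cc1NS(=O)(=O)c1ccc(F)cc1`: 17900 nM

All three compounds show weak activity on the numbers available. Compound 1 has no exact value, because it stands at the limit of > 40000 nM in this assay, at which 1 of the 3 values shown sits. Compound 2 gives 38200 nM, and compound 3 gives 17900 nM.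

The next compound to be tested is compound 4 `O=C1COc2ccc(-c3cnc4ccccc4c3)cc2N1c1ccc(Cl)cc1`. It keeps the core of compound 1 and changes a single group, with chloro in place of methyl on an aromatic carbon, para to a large group: 4-methylphenyl to 4-chlorophenyl (chloro in place of methyl on an aromatic carbon).

Going by the values given here, no measured pair of compounds shows this change on its own, so any forecast is uncertain. One indirect clue is that compound 3 also carries 4-chlorophenyl and gives 17900 nM, although it differs from compound 4 elsewhere in the structure. A small shift toward stronger inhibition is therefore expected in this assay, and it may not exceed the usual scatter. The estimated change is an at least 1.3-fold lower number from compound 1 to compound 4 (0.12 log units; that floor lies within the scatter). Another reading at the assay limit is also possible. For compound 4, the expected value is 30000 nM, with an estimated range of 12000 nM to 60000 nM.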

Compound 4, half-maximal inhibitory concentration: 32700 nM
Beside the measured number, compound 4's estimate is 1.1-fold (0.04 log units) below it; the measured number falls inside the stated range.
By their numbers in this assay, from the lowest: compounds 3, 4 and 2 (each within the scatter of the next, the first and the last beyond it). At a limit, above all of these: compound 1.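

In this assay, going by these compounds alone, the swap of 4-methylphenyl to 4-chlorophenyl gives the first direct reading at this position on the shared core (an at least 1.2-fold lower number from compound 1 to compound 4 (0.08 log units; that floor lies within the scatter)). Going by these compounds, compound 1 gives > 40000 nM, which is a limit and not a number, so the step has only a floor and its true size stays unknown: the limit of > 40000 nM in this assay, at which 1 of the 4 values shown sits. Compound 4 does give a measured number, 32700 nM, so chloro at this place brings a reading inside the range of the assay, but the activity remains weak. The floor of the step does not clear the scatter.

On these data alone, one swap at one position cannot show how this place responds in general, and it remains open whether an amine, a carboxylic acid or a longer chain on the same aromatic carbon would move the number further in either direction. Compound 3 also carries 4-chlorophenyl but differs from compound 4 elsewhere, so the pair says nothing about this change, and whether the swap would act the same way on a different group at the other end of the core is also unknown.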